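A cyano added twice, with no readable step yet

The source may report more compounds than this note shows. Statements on the series, on what has been measured and on what is new or still open speak of the compounds shown alone.

Compound 1 `O=C(NCc1ccc(OCc2ccccc2)cc1)n1cccn1` and compound 2 `N#Cc1cnn(C(=O)NCc2ccc(OCc3ccccc3)cc2)c1` share one core and differ by cyano in place of hydrogen on an aromatic carbon. In an assay on membranes from brain for binding affinity to neutral cholesterol ester hydrolase 1 (Mus musculus), read by fluorescence, with stated times of 1 h and 30 min (a lower number here means a stronger inhibitor, a higher number a weaker inhibitor), compound 1 gives only a limit, > 100000 nM. Compound 2 likewise reaches only the limit in this assay, at > 100000 nM. The step that the two limits leave unreadable from compound 1 to compound 2 is therefore of unreadable size, a point recorded as the limit of > 100000 nM in this assay, at which 3 of the 3 values shown sit. Compound 3 `CN(CCN(C)C(=O)n1cccn1)Cc1cccc(OCc2ccccc2)c1` carries a different core; how it differs from the core of compound 1 is not broken down here. In this assay compound 3 also gives only a limit, > 100000 nM. Compound 4 `CN(CCN(C)C(=O)n1cc(C#N)cn1)Cc1cccc(OCc2ccccc2)c1` is not yet measured and differs from compound 3 by cyano in place of hydrogen on an aromatic carbon, the same change as that from compound 1 to compound 2, at the same place. The step of a number no higher from compound 3 to compound 4 (the limit leaves the size open) is expected to be small or unreadable, because the earlier step that the two limits leave unreadable from compound 1 to compound 2 could not be read. Compound 4 is estimated at 100000 nM, with a likely range of 30000 nM to 300000 nM, and most probably this assay will again return only a limit.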

Compound 4, half-maximal inhibitory concentration: > 100000 nM
Compound 4 ended at the assay's limit (the forecaster's own chance of this, stated with the estimate: 85%); the middle value lies on the limit itself.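

The step from compound 3 to compound 4 cannot be read, since both give only a limit in this assay, and all the compounds shown stand at the same point: the limit of > 100000 nM in this assay, at which 4 of the 4 values shown sit.

What the compounds shown leave open is whether cyano in place of hydrogen on an aromatic carbon changes inhibition at all, and how far each compound lies beyond the limit.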